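The compounds below may be only part of what the source reports. "The series", "measured", "known", "first", "only" and "open" are said of these compounds alone.

Compound 1 `N#CC1=C(N)Oc2c(c3nc4ccccc4nc3c3ccccc23)C12C(=O)N(Cc1cnnn1-c1ccc([N+](=O)[O-])cc1)c1ccccc12` carries a 4-nitrophenyl group on an aromatic nitrogen of a five-membered aromatic ring with 3 nitrogen. In an ADME assay on L02 cells (Homo sapiens) for antiproliferative activity, read by MTT assay, with a stated time of 48 h (a higher number here means a weaker inhibitor, a lower number a stronger inhibitor), compound 1 gives only a limit of the assay, > 50000 nM. Compound 2 `Cc1ccc(-n2nncc2CN2C(=O)C3(C(C#N)=C(N)Oc4c3c3nc5ccccc5nc3c3ccccc43)c3ccccc32)cc1C` differs from compound 1 in a single place: 3,4-dimethylphenyl in place of 4-nitrophenyl on an aromatic nitrogen. In this assay compound 2 likewise reaches only a limit, > 50000 nM. The step that the two limits leave unreadable from compound 1 to compound 2 cannot be sized because the limit of > 50000 nM in this assay, at which 3 of the 3 values shown sit, is where both readings sit.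

Compound 3 `N#CC1=C(N)Oc2c(N)cc3nc4ccccc4nc3c2C12C(=O)N(Cc1cnnn1-c1ccc([N+](=O)[O-])cc1)c1ccccc12` keeps the 4-nitrophenyl group but rests on a different core; the difference between the core of compound 1 and the core of compound 3 is not broken down here. In this assay compound 3 also gives only a limit, > 50000 nM.

Compound 4 `Cc1ccc(-n2nncc2CN2C(=O)C3(C(C#N)=C(N)Oc4c(N)cc5nc6ccccc6nc5c43)c3ccccc32)cc1C` is the not yet measured partner of compound 3, obtained by the change that turned compound 1 into compound 2: 3,4-dimethylphenyl in place of 4-nitrophenyl on an aromatic nitrogen. The place of the change is described in the same words for both pairs, so it is the same change. Going by the values given here, because the limit of > 50000 nM in this assay, at which 3 of the 3 values shown sit, holds every measured value, there is no sized step to lean on, only the observation that none of the three compounds shows measurable activity here. The expected step in this assay is a step that the limit leaves unreadable from compound 3 to compound 4, standing beside the earlier unreadable one. For compound 4 the estimate in this assay is 70000 nM, with a likely range from 30000 nM to 250000 nM, and the most probable outcome is that the assay again reports only its limit.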

Compound 4, half-maximal inhibitory concentration: > 50000 nM
Compound 4: only a limit was reported; the forecaster's own chance of this, stated with the estimate: 85%; the middle value does not contradict the limit.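

In this assay compound 4 gives only a limit of the assay, > 50000 nM. Going by these compounds alone, no step from compound 3 to compound 4 can be read, because both readings sit at the same limit: the limit of > 50000 nM in this assay, at which 4 of the 4 values shown sit. The compounds shown leave open whether 3,4-dimethylphenyl in place of 4-nitrophenyl changes activity in this assay on either core, and none of them yet gives an actual number there.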